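A few compounds are considered here, and "the series" means these few. Any claim that something is new, unique, unknown or untested is made for them only; others in the source may bear on it.

Measured compounds:
compound 1, `O=S(=O)(NCCCNCc1ccccc1Cl)c1cc(C(F)(F)F)cc(C(F)(F)F)c1` — 13000 nM
compound 2, `O=S(=O)(NCCCCNCc1ccc(Br)cc1)c1cc(C(F)(F)F)cc(C(F)(F)F)c1` — 2900 nM
compound 3, `O=S(=O)(NCCCNCc1ccc(C(F)(F)F)cc1)c1cc(C(F)(F)F)cc(C(F)(F)F)c1` — 2000 nM

In a functional assay on ASPC1 cells (Homo sapiens) for inhibition, read by MTT assay, with a stated time of 72 h (a higher number here means a weaker inhibitor of growth, a lower number a stronger inhibitor of growth), compound 1 gives the highest number of the three, so it is the weakest grower-inhibitor shown. Compound 4, `O=S(=O)(NCCCNCc1ccc(Br)cc1)c1cc(C(F)(F)F)cc(C(F)(F)F)c1`, has not yet been measured there. It differs from compound 1 in one place: 4-bromophenyl in place of 2-chlorophenyl on a saturated chain carbon bound to an amine nitrogen. For the measured compounds named here, two measured steps bear on this. a 4.5-fold lower number from compound 1 to compound 2 (0.65 log units; beyond the scatter) brings in the same 4-bromobenzyl group, though with a longer chain as well; a 6.5-fold lower number from compound 1 to compound 3 (0.81 log units; beyond the scatter) swaps the same 2-chlorophenyl for another group carried on the same chain carbon. Both point the same way, so a step of that order is expected in this assay, towards a lower number. Compound 4 is therefore estimated at 3000 nM, with a range of 1400 nM to 7000 nM, an expected change of a 4.3-fold lower number from compound 1 to compound 4 (0.64 log units; beyond the scatter).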

Compound 4, concentration for 50% growth inhibition: 2800 nM
The estimate for compound 4 lay 1.1-fold (0.03 log units) above the measured number; the measured number falls inside the stated range.
By their numbers in this assay, from the lowest: compounds 3, 4 and 2 (each within the scatter of the next); then compound 1.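

In this assay, 4-bromophenyl in place of 2-chlorophenyl on the unchanged chain gives a 4.6-fold lower number from compound 1 to compound 4 (0.67 log units; beyond the scatter), so this single change accounts for a step beyond the scatter. Neither bromo against trifluoromethyl, with a 1.4-fold higher number from compound 3 to compound 4 (0.15 log units; within the scatter), nor the chain length, with a 1.0-fold lower number from compound 2 to compound 4 (0.02 log units; within the scatter), separates these compounds beyond the scatter. No measurement shown explains these results. A 4-chlorophenyl or 2-bromophenyl group would help separate the effect of the halogen from that of its place on the ring.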